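This account rests on a few compounds, and the source may have more. Where it says the series, first, only, none or still open, it means among the compounds named here.

In an assay (Rattus norvegicus) for inhibition of Fatty-acid amide hydrolase 1 (Homo sapiens) (on this read-out lower numbers stand for stronger inhibition and higher numbers for weaker inhibition), compound 2 `N#Cc1cccc(-c2cnc(C(=O)CCCCCCc3ccccc3)o2)c1` gives 15 nM, the lower of the two numbers shown; the nearest is compound 1 `O=C(CCCCCCc1ccccc1)c1ncc(-c2cccc(C(=O)C(F)(F)F)c2)o1`, which gives 16 nM, and the step of a 1.1-fold lower number from compound 1 to compound 2 (0.03 log units; within the scatter) is the only measured one. Compound 3 `Cc1ccnc(-c2cnc(C(=O)CCCCCCc3ccccc3)o2)c1` differs from compound 2 on an aromatic carbon of the shared core: 4-methylpyridin-2-yl in place of 3-cyanophenyl on an aromatic carbon. Going by the values given here, the one measured step exchanged a substituent while keeping the six-membered ring of carbon only in place, so it does not speak directly to replacing the whole 3-cyanophenyl with 4-methylpyridin-2-yl. Among the compounds with values here, with no step bearing on this change, the account expects for compound 3 a number close to that of compound 2, a step of a 1.7-fold higher number from compound 2 to compound 3 (0.22 log units; within the scatter) of no clear direction beyond the scatter. Compound 3 is therefore estimated at 25 nM in this assay, between 6 nM and 100 nM.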

Compound 3, inhibition constant: 0.6 nM
The estimate for compound 3 lay 42-fold (1.62 log units) above the measured number; measured number outside the range, below it.
By their numbers in this assay, from the lowest: compound 3; then compounds 2 and 1 (each within the scatter of the next).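

In this assay the position next to the ring oxygen proves highly sensitive to the ring it carries: 4-methylpyridin-2-yl in place of 3-cyanophenyl gives a 25-fold lower number from compound 2 to compound 3 (1.40 log units; beyond the scatter) and stands apart from the earlier substituent exchange on the six-membered ring of carbon only, a 1.1-fold lower number from compound 1 to compound 2 (0.03 log units; within the scatter). Going by these compounds alone, the new change alters several things at once, since the ring gains a hetero atom, a methyl enters and the nitrile leaves, so the single step cannot be divided among them. No measurement at hand accounts for the size of this step.

The compounds shown do not separate the ring nitrogen from the methyl: a plain pyridin-2-yl and a 4-methylphenyl would each carry only one of the two. Also open, on these data alone, is how the pyridine ring would read in this assay with an amine or a carboxylic acid in place of the methyl.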